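A para-substituent swap on a pyrazolyl amide series

This account rests on a few compounds, and the source may have more. Where it says the series, first, only, none or still open, it means among the compounds named here.

Measured so far:
compound 1, `CC(C(=O)Nc1cc(C2CC2)[nH]n1)c1ccc(-n2cnnc2O)cc1`, 8390 nM in a functional assay on A2780 cells (Homo sapiens) for inhibition; a lower number here means a stronger inhibitor, a higher number a weaker inhibitor
compound 2, `C[C@@H](C(=O)Nc1cc(C2CC2)[nH]n1)c1ccc(N2CCNC2=O)cc1`, 13200 nM
compound 3, `C[C@H](C(=O)Nc1cc(C2CC2)[nH]n1)c1ccc(N2Cc3ccccc3C2=O)cc1`, 1020 nM

Among these three numbers in this assay, compound 1 holds the second highest. Its nearest neighbour is compound 2, which lies within the usual scatter of it, so the two cannot be placed in order. Compound 3 is the furthest away, with a number well beyond the scatter below that of compound 1.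

The unmeasured compound 4, `CC(C(=O)Nc1cc(C2CC2)[nH]n1)c1ccc(N2CCCS2(=O)=O)cc1`, is reached from compound 1 by a single change: a group of 7 heavy atoms (3 carbon, 1 nitrogen, 2 oxygen, 1 sulfur; one five-membered non-aromatic ring with 2 hetero atoms) in place of a group of 6 heavy atoms (2 carbon, 3 nitrogen, 1 oxygen; one five-membered aromatic ring with 3 hetero atoms), on an aromatic carbon. Among the measured compounds shown here, no pair of compounds that differ in only one place has been measured, so the size of this step has no precedent here; what is known is only that a five-membered ring bearing a donor, in compound 2, sits near compound 1, while the bicyclic group of compound 3 sits far lower.

The step from compound 1 to compound 4 is expected to be small, a 1.2-fold lower number from compound 1 to compound 4 (0.08 log units; within the scatter), likely within the scatter. Compound 4 is therefore estimated at 7000 nM in this assay, with a range from 2000 nM to 25000 nM.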

Compound 4, half-maximal inhibitory concentration: 5240 nM
Compound 4: middle estimate off by 1.3-fold (0.13 log units), on the high side; measured number inside the range.
By their numbers in this assay, from the lowest: compound 3; then compounds 4, 1 and 2 (each within the scatter of the next, the first and the last beyond it).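

In this assay, putting the five-membered non-aromatic ring with 2 hetero atoms in place of the five-membered aromatic ring with 3 hetero atoms, on an aromatic carbon para to a large group, gives a 1.6-fold lower number from compound 1 to compound 4 (0.20 log units; within the scatter). Among the compounds shown here, this is the first single-place step in the set, and it shows that these two groups cannot be told apart at this position, even though the entering group has 0 hydrogen-bond donors and 2 hydrogen-bond acceptors, against 1 donor and 4 acceptors in the group that leaves. Nothing measured here bears on why the two groups give such similar numbers.

Still open, from the compounds shown here alone, is whether an open-chain group at this carbon, such as an amine or a carboxylic acid, would also stay within the scatter of compound 1. Also open, going by these compounds, is whether a six-membered ring such as morpholine would do so.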